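The compounds below may be only part of what the source reports. "The series", "measured", "known", "first", "only" and "open" are said of these compounds alone.

Measured compounds:
compound 1 `COc1cc(CNCCCN(C)C)ccc1OCc1ccc(Cl)nc1`: 5000 nM
compound 2 `COc1cc(CNc2nc[nH]n2)ccc1OCc1ccc(Cl)nc1`: 69000 nM
compound 3 `COc1cc(CNCc2ccc(C(=O)O)cc2)ccc1OCc1ccc(Cl)nc1`: "nd(insoluble)" (no result reported)

Going by the values given here, in a functional assay on HeLa cells (Homo sapiens) for inhibition, with a stated time of 72 h (a lower number here means that less compound is needed, a higher number that more compound is needed for the effect), compound 1 gives 5000 nM and compound 2 gives 69000 nM; the one measured step, a 14-fold higher number from compound 1 to compound 2 (1.14 log units; beyond the scatter), is the only comparison available. Compound 3 stands nowhere on these numbers: in this assay compound 3 gives "nd(insoluble)" (no result reported), so no value is known for it. Compound 4 `COCCNCc1ccc(OCc2ccc(Cl)nc2)c(OC)c1` differs from compound 3 by methoxymethyl in place of 4-carboxyphenyl on a saturated chain carbon bound to an amine nitrogen. Among the compounds with values here, the single measured step concerns a substituent on an amine nitrogen, not a saturated chain carbon, so it does not bear directly on this change, and no step size can be computed from compound 3. The open chain of compound 4 is closer to that of compound 1 than to the ring of compound 2, and compound 4 is expected to give about 30000 nM, in the range 8000 nM to 120000 nM.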

Compound 4, half-maximal effective concentration: 97000 nM
Estimate against measurement, compound 4: 3.2-fold (0.51 log units) below; low and high end bracket the measured number.
By their numbers in this assay, from the lowest: compound 1; then compounds 2 and 4 (each within the scatter of the next).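

In this assay, 2-methoxyethyl on the amine nitrogen and 1H-1,2,4-triazol-3-yl in the same place give a 1.4-fold higher number from compound 2 to compound 4 (0.15 log units; within the scatter), so an open chain and this ring are not told apart here. Methoxy in place of (dimethylamino)methyl on a saturated chain carbon, two bonds along the chain from an amine nitrogen, gives a 19-fold higher number from compound 1 to compound 4 (1.29 log units; beyond the scatter), so an open chain alone does not bring compound 4 to the level of compound 1. No measurement shown here accounts for this difference.

Going by these compounds, how a piperidine or a longer chain ending in an amine would compare with compound 1 stays open. Compound 3 gives no value, so its steps cannot be read.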